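The compounds below may be only part of what the source reports. "The series", "measured", "known", "first", "only" and "open" are said of these compounds alone.

Notes on the series. The shared core is carried by compound 1 `CCCC[C@@H](C)C[C@@H](C)C(=O)N(C)[C@@H](C=C(C)C)C(=O)N[C@H](C(=O)N(C)[C@H](C(=O)N1CCC[C@H]1C(=O)N1C(=O)C=C[C@@H]1C)C(C)C)[C@@H](C)OC(C)=O` and compound 2 `CCCC[C@@H](C)C[C@@H](C)C(=O)N(C)[C@@H](C=C(C)C)C(=O)N[C@H](C(=O)N(C)[C@H](C(=O)N1C[C@@H](O)C[C@H]1C(=O)N1C(=O)C=C[C@@H]1C)C(C)C)[C@@H](C)OC(C)=O`, which differ by a hydroxy in place of hydrogen on a saturated ring carbon. In a functional assay on NCI-H460 cells (Homo sapiens) for cytotoxicity, read by MTT assay, with a stated time of 48 h (a higher number here means a weaker inhibitor, a lower number a stronger inhibitor), compound 1 gives 1000 nM, and in this assay compound 2 gives 37 nM. That single change produced a 27-fold lower number from compound 1 to compound 2 (1.43 log units; beyond the scatter), so compound 2 stands at the lower of the two numbers, its nearest neighbour compound 1 being the higher one.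

Compound 3 `CCCC[C@@H](C)C[C@@H](C)C(=O)N(C)[C@@H](C=C(C)C)C(=O)N[C@H](C(=O)N(C)[C@H](C(=O)N1C[C@@H](O)C[C@H]1C(=O)N1C(=O)C=C[C@@H]1C)C(C)C)[C@@H](C)O` keeps the hydroxy on the saturated ring carbon and differs from compound 2 only at the 1-acetoxyethyl side chain: hydrogen in place of acetyl on an oxygen on a saturated carbon, i.e. acetoxy to hydroxy. Within the data shown here, no measured step touches that oxygen; the one step known, from compound 1 to compound 2, concerns a different position and gives no guide to the size or direction of the present change. With nothing to lean on, the working expectation for this assay is a step of no more than the usual scatter in either direction, a 1.6-fold higher number from compound 2 to compound 3 (0.21 log units; within the scatter), though a larger shift cannot be excluded. Compound 3 is therefore estimated at 60 nM, with a range of 15 nM to 300 nM.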

Compound 3, half-maximal inhibitory concentration: 160 nM
Compound 3: the middle estimate sits 2.7-fold (0.43 log units) below what was measured; measured number inside the range.
By their numbers in this assay, from the lowest: compound 2; then compound 3; then compound 1.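

The 1-acetoxyethyl side chain is shown here to matter for this read-out: in this assay, acetoxy to hydroxy gives a 4.3-fold higher number from compound 2 to compound 3 (0.64 log units; beyond the scatter) and so moves towards a weaker inhibitor, which means the acetyl on this oxygen is not a silent feature of the series. The step is modest, and compound 3 with its free 1-hydroxyethyl group still gives 160 nM in this assay, so losing the acetyl reduces the activity of compound 2 without abolishing it. Nothing available explains why this change has this effect.

The compounds shown do not tell whether the acetyl itself counts or whether another group on this oxygen, such as a propionyl or benzoyl ester or a methyl ether, would give a similar number. Acetoxy to hydroxy is also seen only with the hydroxy on the saturated ring carbon in place, so its size on the unsubstituted ring of compound 1 remains open, as does the effect of an amine in place of this oxygen.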